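Hydroxyphenyl in Place of Fluorophenyl on a Sulfonyl Anilide

The compounds below may be only part of what the source reports. "The series", "measured", "known", "first", "only" and "open" are said of these compounds alone.

Measured compounds:
compound 1 `CC(O)(C(=O)Nc1ccc(S(=O)(=O)c2ccc(F)cc2)cc1)C(F)(F)F` – 8600 nM
compound 2 `CC(O)(C(=O)Nc1ccc(S(=O)(=O)c2ccccc2)c(O)c1)C(F)(F)F` – 430 nM

In a functional assay (Cavia porcellus) with sulfonylurea receptors; K-ATP channels (Homo sapiens) as the target (on this read-out higher numbers stand for weaker inhibition and lower numbers for stronger inhibition), compound 1 gives 8600 nM, the higher of the two numbers; compound 2, which is not a single-change neighbour of it, gives 430 nM, a gap beyond the scatter. Compound 3 `CC(O)(C(=O)Nc1ccc(S(=O)(=O)c2cccc(O)c2)cc1)C(F)(F)F` carries 3-hydroxyphenyl in place of 4-fluorophenyl on a sulfonyl sulfur. Among the measured compounds shown here, no single-change step between measured compounds bears on this exchange, so the expectation rests on the two values alone. A step downward from compound 1 to compound 3 of a 2.9-fold lower number from compound 1 to compound 3 (0.46 log units; beyond the scatter) is expected, modest and uncertain. Compound 3 is thus estimated at 3000 nM, with a range from 800 nM to 12000 nM.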

Compound 3, half-maximal inhibitory concentration: 18000 nM
Beside the measured number, compound 3's estimate is 6.0-fold (0.78 log units) below it; measured number outside the range, above it.
By their numbers in this assay, from the lowest: compound 2; then compound 1; then compound 3.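

In this assay, among the compounds shown here, putting 3-hydroxyphenyl in place of 4-fluorophenyl on a sulfonyl sulfur gives a 2.1-fold higher number from compound 1 to compound 3 (0.32 log units; beyond the scatter), the only single-change step at this position, and it points toward weaker inhibition. The exchange therefore shows that a hydroxyphenyl on this sulfur does not by itself bring a lower number. No measurement shown here accounts for this step.

On these data alone, whether a methoxy group or an amine in place of the hydroxyl would shift the number in the same direction remains open, as does the effect of a 4-hydroxyphenyl group on the same sulfur.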